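The source may hold more compounds than are shown below. What is called first, only, known or untested is meant among the compounds shown, and "the series" means these compounds.

In a functional assay on HeLa cells (Homo sapiens) for cytotoxicity, read by WST assay, with a stated time of 48 h (a lower number here means a stronger inhibitor, a higher number a weaker inhibitor), compound 3 `COc1ccc(/C=C/C[C@H]2C[C@@H]([C@@H](O)c3ccccc3)CO[C@@H]2c2ccc(OC)c(OC)c2)cc1OC` gives 15500 nM. This is within the scatter of compound 2 `Oc1ccc(/C=C/C[C@H]2C[C@@H]([C@@H](O)c3ccccc3)CO[C@@H]2c2ccccc2)cc1` at 14400 nM, while compound 1 `COc1ccc([C@H](O)[C@H]2CO[C@H](c3ccc(OC)c(OC)c3)[C@@H](C/C=C/c3ccc(OC)c(OC)c3)C2)cc1` stands higher at 46000 nM. Compound 4 `COc1ccc(/C=C/C[C@@H]2C[C@@H]([C@@H](O)c3ccccc3)CO[C@H]2c2ccc(OC)c(OC)c2)cc1OC` has the same atoms and bonds as compound 3 and differs only in configuration as drawn: the two compounds have the same atoms and bonds and differ only in configuration as drawn: 2 of 5 stereo elements differ; a stereocentre at a saturated ring carbon is drawn S in compound 3 and R in compound 4; a stereocentre at a saturated ring carbon is drawn S in compound 3 and R in compound 4. Two stereocentres at saturated ring carbons that are drawn S in compound 3 are drawn R in compound 4. Within the data shown here, the only measured step between compounds differing in one place is a 3.0-fold lower number from compound 1 to compound 3 (0.47 log units; beyond the scatter), which puts hydrogen in place of methoxy on an aromatic carbon. Among the measured compounds shown here, that step involves no change of configuration, so it offers only a rough sense of scale, and no measured pair shows what such a change does. With no direction favoured, no shift beyond the scatter is expected, although the range must stay wide. The expected step is a 1.2-fold higher number from compound 3 to compound 4 (0.06 log units; within the scatter). Compound 4 is estimated at 18000 nM, with an expected range of 6000 nM to 55000 nM.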

Compound 4, half-maximal inhibitory concentration: 16800 nM
Compound 4: the middle estimate sits 1.1-fold (0.03 log units) above what was measured; the range from low to high includes it.
By their numbers in this assay, from the lowest: compounds 2, 3 and 4 (each within the scatter of the next); then compound 1.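

In this assay, the result is a 1.1-fold higher number from compound 3 to compound 4 (0.03 log units; within the scatter), so drawing the two saturated ring carbons R rather than S leaves no readable difference in this pair. Among these compounds, the earlier compounds offered only a step that replaced methoxy with hydrogen on an aromatic carbon, so this is the first measured pair to test configuration, and the finding applies to this pair alone. The comparison isolates configuration, with nothing else varying: the fact that compounds 3 and 4 differ only in the configuration as drawn.

On these data alone, each of the two ring carbons changes together with the other here, so the effect of either one alone remains open, as does the effect of changing the remaining stereo elements. It is also unknown whether configuration would matter as little with an amine or a carboxylic acid in place of the hydroxyl group.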